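Methoxy added to the compound 2 aryl ring

The source may report more compounds than this note shows. Statements on the series, on what has been measured and on what is new or still open speak of the compounds shown alone.

Measured so far:
compound 1 `COc1ccc(-c2cc(C(=O)Nc3nc4ccc(Cl)cc4s3)nc3cc(-c4ccccc4)nn23)cc1OC` — 6160 nM
compound 2 `COc1ccc(-c2cc(C(=O)Nc3nc4ccc(F)cc4s3)nc3cc(-c4ccccc4)nn23)cc1` — 11700 nM

In a functional assay on A549 cells (Homo sapiens) for cytotoxicity, read by MTT assay, with a stated time of 48 h (on this read-out lower numbers stand for stronger inhibition and higher numbers for weaker inhibition), compound 2 gives 11700 nM, the higher of the two numbers; compound 1 sits at 6160 nM, and the gap between them lies within the scatter. Compound 3 `COc1ccc(-c2cc(C(=O)Nc3nc4ccc(F)cc4s3)nc3cc(-c4ccccc4)nn23)cc1OC` is unmeasured. It differs from compound 2 by methoxy in place of hydrogen on an aromatic carbon, so compound 3 carries the same 3,4-dimethoxyphenyl as compound 1 on the shared core. Within the data shown here, no measured pair isolates this change, so the step from compound 2 to compound 3 is expected to be modest, if anything toward a lower number, and estimated at a 1.5-fold lower number from compound 2 to compound 3 (0.17 log units; within the scatter). Compound 3 is expected at 8000 nM, between 3500 nM and 18000 nM.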

Compound 3, half-maximal inhibitory concentration: 6910 nM
Beside the measured number, compound 3's estimate is 1.2-fold (0.06 log units) above it, within the range that was stated.
By their numbers in this assay, from the lowest: compounds 1, 3 and 2 (each within the scatter of the next).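

In this assay the change from 4-methoxyphenyl to 3,4-dimethoxyphenyl, now read directly, gives a 1.7-fold lower number from compound 2 to compound 3 (0.23 log units; within the scatter) and does not separate the two compounds. Fluoro in place of chloro on the otherwise unchanged compound gives a 1.1-fold higher number from compound 1 to compound 3 (0.05 log units; within the scatter) and does not separate that pair either. No supporting data bear on these steps.

Still open, as far as these compounds go, is whether an amine or a carboxylic acid on this aromatic carbon, ortho to a methoxy group, would give a step beyond the scatter. The same question stands for a longer alkoxy chain there.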